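The source may report more compounds than this note shows. Statements on the series, on what has been measured and on what is new or still open speak of the compounds shown alone.

Measured so far:
Compound 1, `COC(=O)[C@H](CCSC)NC(=O)c1ccc(CNCc2c[nH]cn2)cc1-c1ccccc1C`: 25 uM
Compound 2, `CSCC[C@H](NC(=O)c1ccc(NCc2cncn2Cc2ccccc2C#N)cc1-c1ccccc1)C(=O)O`: > 10 uM
Compound 3, `COC(=O)[C@H](CCSC)NC(=O)c1ccc(NCc2cncn2Cc2cccc(C#N)c2)cc1-c1ccccc1`: > 10 uM

All three were tested in a functional assay on NIH3T3 cells (Mus musculus); on this read-out higher numbers stand for an effect only at larger amounts of compound and lower numbers for an effect already at smaller amounts. For the measured compounds named here, compound 1 gives 25 uM, the only plain number among the three. For compound 2 the result is a limit of the assay, > 10 uM. For compound 3 the result is likewise a limit, > 10 uM. Going by the values given here, compound 1 thus stands alone as the one compound with a number, while two of the three results sit at the limit of > 10 uM in this assay, at which 2 of the 3 values shown sit.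

Compound 4, `CSCC[C@H](NC(=O)c1ccc(CNCc2c[nH]cn2)cc1-c1ccccc1C)C(=O)O`, has not yet been measured in this assay. It differs from compound 1 in one place: hydrogen in place of methyl on an oxygen next to a carbonyl group. Among the compounds with values here, no pair of measured compounds differs by exactly this change, so there is no measured step to lean on. Compound 2 also carries a carboxy group, but it differs from compound 1 in several further places as well, so it cannot stand in for this step.

With nothing measured to guide it, the step from compound 1 to compound 4 in this assay is expected to be small, a 1.4-fold higher number from compound 1 to compound 4 (0.15 log units; within the scatter), perhaps slightly toward weaker effect, and not clearly beyond the scatter. Compound 4 is therefore estimated at 35 uM, with a range from 8 uM to 150 uM.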

Compound 4, concentration for half-maximal effect: > 25 uM
Compound 4 was reported as a limit; the forecaster's own chance of this, stated with the estimate: 45%; the middle value does not contradict the limit.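

For the compounds shown here, at this position, the one place where compound 1 and compound 4 differ, methoxycarbonyl gives way to carboxy, with hydrogen in place of methyl on an oxygen next to a carbonyl group, and the read-out shows a number no lower from compound 1 to compound 4 (the limit leaves the size open). In this assay compound 4 gives > 25 uM, which is a limit and not a number. This makes the change the first one here that can be followed in a single place, and its direction is the only thing it gives, since the result sits at a limit: the limit of > 25 uM in this assay, at which 1 of the 4 values shown sits.

The compounds shown leave open how large this step really is. They also leave open how this assay would read with ethoxycarbonyl, a longer ester, or with a primary amide at the same place.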